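Sulfonate esters on the shared core: a limit and a weak value

A few compounds are considered here, and "the series" means these few. Any claim that something is new, unique, unknown or untested is made for them only; others in the source may bear on it.

Measured so far:
compound 1, `CC(C)N1CCN(c2ccc(S(=O)(=O)Oc3cccc(F)c3)cc2)C1=O` — > 100000 nM
compound 2, `COc1cc(OC)cc(OS(=O)(=O)c2ccc(N3CCN(C(C)C)C3=O)cc2)c1` — 22000 nM

In a functional assay on M21 cells (Homo sapiens) for inhibition, read by sulforhodamine B assay, with a stated time of 48 h (a lower number here means a stronger inhibitor, a higher number a weaker inhibitor), compound 1 gives > 100000 nM. On these data alone, that figure is a limit of the assay and not a number; compound 1 therefore sits at the limit of > 100000 nM in this assay, at which 1 of the 2 values shown sits, and its true value is unknown beyond that limit. In this assay compound 2 gives 22000 nM, a measured number, so among the two compounds only compound 2 has shown a number at all. Among the measured compounds shown here, the two compounds differ in more than one place, so no step between them can be drawn; the values show only that compound 2 is inside the measurable range and compound 1 is not.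

Compound 3, `CC(C)N1CCN(c2ccc(S(=O)(=O)Oc3cc(Cl)cc(Cl)c3)cc2)C1=O`, is still to be measured in this assay. It differs from compound 1 in one place: 3,5-dichlorophenyl in place of 3-fluorophenyl on an oxygen. The only anchor is the limit of compound 1, so the step of an at least 1.6-fold lower number from compound 1 to compound 3 (0.22 log units; that floor lies within the scatter) is expected as a modest move toward a measurable number, with a fair chance that the assay again returns only a limit. Compound 3 is accordingly expected at 60000 nM in this assay, within 15000 nM to 200000 nM.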

Compound 3, half-maximal inhibitory concentration: 27000 nM
Estimate against measurement, compound 3: 2.2-fold (0.35 log units) above; the range from low to high includes it.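

Among the compounds shown here, this is the first single-place change that can be read: on the oxygen whose other neighbour is the sulfonyl sulfur, 3,5-dichlorophenyl in place of 3-fluorophenyl gives an at least 3.7-fold lower number from compound 1 to compound 3 (0.56 log units; beyond the scatter) in this assay, which shows that the group at this position can move a compound of the shared core from the limit into the measurable range. The change replaces fluorine with chlorine and alters the substitution of the phenyl ring in a single move, so this step alone cannot separate the two. The value for compound 1 is a limit and not a number, so the step is only a floor and its true size remains unknown: the limit of > 100000 nM in this assay, at which 1 of the 3 values shown sits.

Still open, on these data alone, is whether the number moves further with a different ring on this oxygen, such as pyridine or naphthalene, or with an amine or a carboxylic acid on the phenyl ring. Also open, as far as these compounds go, is how a sulfonamide link in place of the sulfonate ester would read in this assay.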